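Dropping the piperidine ester: cytotoxicity expected to stay at the limit

This account rests on a few compounds, and the source may have more. Where it says the series, first, only, none or still open, it means among the compounds named here.

Measured so far:
Compound 1, `O=C(Nc1cc(-c2nc3ccccc3s2)ccc1F)c1cc([N+](=O)[O-])ccc1Cl`, in an ADME assay on HEK293 cells (Homo sapiens) for cytotoxicity, with a stated time of 72 h (a higher number here means that more compound is needed for the effect, a lower number that less compound is needed), gives > 25000 nM, which is a limit of the assay rather than a number.
Compound 2, `COC(=O)C1CCN(c2cc(Cl)c(C(=O)Nc3cc(-c4nc5ccccc5s4)ccc3C)cc2[N+](=O)[O-])CC1`, in this assay gives > 25000 nM, again a limit and not a number.

Compound 2 therefore stands at the edge of what the assay can report, together with compound 1, as the limit of > 25000 nM in this assay, at which 2 of the 2 values shown sit, shows. Compound 3, `Cc1ccc(-c2nc3ccccc3s2)cc1NC(=O)c1cc([N+](=O)[O-])ccc1Cl`, has not yet been measured. It differs from compound 2 in one place: hydrogen in place of 4-(methoxycarbonyl)piperidin-1-yl on an aromatic carbon. No measured pair here isolates this change, so the expectation rests only on the two limits shown. The step from compound 2 to compound 3 in this assay is expected to be a step that the limit leaves unreadable from compound 2 to compound 3, nothing beyond the scatter, since compound 1 and compound 2 both sit at the limit. Compound 3 is estimated to give 40000 nM in this assay, within 20000 nM to 100000 nM, most likely reported as a limit again.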

Compound 3, half-maximal effective concentration: > 14000 nM
Compound 3: no number, only a limit; the forecaster's own chance of this, stated with the estimate: 85%; the middle value is on the limit's open side.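

In this assay compound 3 gives > 14000 nM, again a limit, so the steps from compound 1 and from compound 2 to compound 3 cannot be read. Still open, from the compounds shown here alone, is the concentration at which any of the three reaches its half-maximal effect, and whether either change shifts it.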